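This account rests on a few compounds, and the source may have more. Where it says the series, first, only, none or still open, it means among the compounds named here.

- Compound 1 `Cc1cc(C)cc(S(=O)(=O)c2c(C(=O)NCC(=O)NC(C)c3ccccc3)[nH]c3ccc(Cl)cc23)c1`: 29400 nM
- Compound 2 `Cc1cc(C)cc(S(=O)(=O)c2c(C(=O)NCC(=O)NCc3ccncc3)[nH]c3ccc(Cl)cc23)c1`: > 48900 nM, a limit of the assay and not a number
- Compound 3 `Cc1cc(C)cc(S(=O)(=O)c2c(C(=O)Nc3ccnc(C#N)c3)[nH]c3ccc(Cl)cc23)c1`: 6840 nM

In an ADME assay on MT4 cells (Homo sapiens) for cytotoxicity, read by MTT assay (a lower number here means that less compound is tolerated, a higher number that more compound is tolerated), compound 1 gives 29400 nM, the higher of the two actual numbers. The nearest value lies at a 4.3-fold lower number from compound 1 to compound 3 (0.63 log units; beyond the scatter).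

Compound 4 `Cc1cc(C)cc(S(=O)(=O)c2c(C(=O)NC(C)C(=O)NC(C)c3ccccc3)[nH]c3ccc(Cl)cc23)c1` alters compound 1 in one place: methyl in place of hydrogen on a saturated chain carbon bound to an amide-type nitrogen and a carbonyl carbon. Among the measured compounds shown here, no measured step makes this change. The closest evidence comes from two swaps of a whole group on an amide-type nitrogen, an at least 1.6-fold higher number from compound 1 to compound 2 (0.22 log units; that floor lies within the scatter) and a 4.3-fold lower number from compound 1 to compound 3 (0.63 log units; beyond the scatter). Since these swaps are much larger than adding one methyl and still gave limited shifts, no change beyond the scatter is expected here. The expected step is a 1.1-fold lower number from compound 1 to compound 4 (0.04 log units; within the scatter). For compound 4 the estimated value is 27000 nM, with an expected range of 12000 nM to 55000 nM.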

Compound 4, half-maximal cytotoxic concentration: 21700 nM
Compound 4: middle estimate off by 1.2-fold (0.09 log units), on the high side; the measured number falls inside the stated range.
By their numbers in this assay, from the lowest: compound 3; then compounds 4 and 1 (each within the scatter of the next). At a limit, above all of these: compound 2.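

Methyl in place of hydrogen on a saturated chain carbon bound to an amide-type nitrogen and a carbonyl carbon gives, in this assay, a 1.4-fold lower number from compound 1 to compound 4 (0.13 log units; within the scatter), so this is the first direct reading at this position. One added methyl here produces no shift beyond the scatter. Nothing shown bears on why this step is so small.

Still open, as far as these compounds go, is whether a longer chain, an amine or a carboxylic acid on this carbon would stay within the scatter as well. The same methyl on compound 2, whose reading is a limit, also remains untested among the compounds shown.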